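The source may report more compounds than this note shows. Statements on the series, on what has been measured and on what is new or still open speak of the compounds shown alone.

Compound 1 `COCCOc1nc(N)nc2c1ncn2/C=C1/CC1(CO)CO` gives in an ADME assay on HFF cells (Homo sapiens) for cytotoxicity, with a stated time of 8 days (a higher number here means that more compound is tolerated, a lower number that less compound is tolerated), a value that is only a limit of the assay, > 300000 nM.
Compound 2 `CC(C)Nc1nc(N)nc2c1ncn2/C=C1/CC1(CO)CO` gives in this assay likewise a limit, > 300000 nM.
Compound 3 `Nc1nc2c(ncn2/C=C2/CC2(CO)CO)c(=O)[nH]1` gives in this assay again a limit, > 300000 nM.

Compound 2 thus stands at the limit of this assay, the point where every measured value sits (the limit of > 300000 nM in this assay, at which 3 of the 3 values shown sit). Among the compounds with values here, the one measured step, a step that the two limits leave unreadable from compound 1 to compound 2, has a limit at each end and offers no readable size. Compound 4 `Nc1nc(SC2CCCC2)c2ncn(/C=C3/CC3(CO)CO)c2n1` differs from compound 2 by cyclopentylsulfanyl in place of isopropylamino on an aromatic carbon. Within the data shown here, no measured step touches a cyclopentylsulfanyl group, so nothing in the data points in any direction. A step of an at least 1.5-fold lower number from compound 2 to compound 4 (0.17 log units; that floor lies within the scatter) is therefore expected, essentially none beyond the scatter. Compound 4 is estimated at 200000 nM, in the range 50000 nM to 300000 nM.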

Compound 4, half-maximal cytotoxic concentration: > 300000 nM
Compound 4: only a limit was reported; the forecaster's own chance of this, stated with the estimate: 60%; middle value at least 1.5-fold (0.17 log units) away from the limit.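

In this assay compound 4 gives > 300000 nM, which is only a limit. The steps to compound 4 from compound 1 and from compound 2 therefore cannot be read: the limit of > 300000 nM in this assay, at which 4 of the 4 values shown sit.

The compounds shown leave open at what concentration any of them becomes cytotoxic.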